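Lengthening One Methoxy Group on a Shared Core

The source may hold more compounds than are shown below. What is called first, only, known or untested is meant among the compounds shown, and "the series" means these compounds.

Three measured compounds share one core and differ only in the methoxy groups on one aromatic ring. In a functional assay on A549 cells (Homo sapiens) for inhibition, read by MTT assay, with a stated time of 48 h (a lower number here means a stronger inhibitor, a higher number a weaker inhibitor), compound 2 `COc1ccc(-c2nc3cc(/C=C4\SC(=O)NC4=O)ccc3[nH]2)cc1OC` gives 570 nM, the lowest of the three numbers shown. Compound 1 `COc1cc(-c2nc3cc(/C=C4\SC(=O)NC4=O)ccc3[nH]2)cc(OC)c1OC` gives 3570 nM and compound 3 `COc1cc(OC)c(-c2nc3cc(/C=C4\SC(=O)NC4=O)ccc3[nH]2)cc1OC` gives 1840 nM. Compound 4 `COc1cc(-c2nc3cc(/C=C4\SC(=O)NC4=O)ccc3[nH]2)ccc1OCC(C)C` carries isopropyl in place of hydrogen on a saturated chain carbon bound to an oxygen on an aromatic ring, so a methoxy becomes an isobutoxy. The measured steps concern adding or removing a whole methoxy on the ring, not lengthening one: a 6.3-fold lower number from compound 1 to compound 2 (0.80 log units; beyond the scatter) and a 3.2-fold higher number from compound 2 to compound 3 (0.51 log units; beyond the scatter). Both show that an added group on that ring went with a modestly higher number, so compound 4 is expected to show a modest rise, a 1.8-fold higher number from compound 2 to compound 4 (0.24 log units; within the scatter). Compound 4 is therefore estimated at 1000 nM, within a range from 300 nM to 3500 nM.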

Compound 4, half-maximal inhibitory concentration: 5110 nM
Beside the measured number, compound 4's estimate is 5.1-fold (0.71 log units) below it, and the stated range ends below it.
By their numbers in this assay, from the lowest: compound 2; then compounds 3, 1 and 4 (each within the scatter of the next, the first and the last beyond it).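

Lengthening a methoxy to an isobutoxy, with no methoxy added to or removed from the ring, still gives a 9.0-fold higher number from compound 2 to compound 4 (0.95 log units; beyond the scatter) in this assay. The number therefore responds not only to how many groups the ring carries but also to the length of one of them, here on a saturated chain carbon bound to an oxygen on an aromatic ring. No measurement here explains this rise.

Open, on these data alone, is whether an ethoxy, a shorter chain, would give a number nearer that of compound 2, and whether an amine or a carboxylic acid at the chain end would change the result.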